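This account rests on a few compounds, and the source may have more. Where it says the series, first, only, none or still open, it means among the compounds named here.

Measured so far in a functional assay on KB cells (Homo sapiens) for antiproliferative activity, read by sulforhodamine B assay, with a stated time of 3 days; on this read-out higher numbers stand for an effect only at larger amounts of compound and lower numbers for an effect already at smaller amounts:
Compound 1 `CCC1=C(O)c2c(oc(-c3ccccc3)cc2=O)C(CC)(CC)C1=O`: > 236 uM, a limit of the assay and not a number
Compound 2 `CCC1=C(O)c2c(oc(-c3ccc(C)cc3)cc2=O)C(CC)(CC)C1=O`: 39.2 uM
Compound 3 `CCC1=C(O)c2c(oc(-c3cccc(C)c3)cc2=O)C(CC)(CC)C1=O`: 49.7 uM

Going by the values given here, compound 3 has only one true number to stand against, and the two cannot be told apart: the data show a 1.3-fold higher number from compound 2 to compound 3 (0.10 log units; within the scatter).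

The next compound to be tested is compound 4 `CCC1=C(O)c2c(oc(-c3ccccc3C)cc2=O)C(CC)(CC)C1=O`. It holds the same atoms as compound 3, joined differently, with 2-methylphenyl in place of 3-methylphenyl on an aromatic carbon, next to the ring oxygen of the shared core (2-methylphenyl in place of 3-methylphenyl on an aromatic carbon).

Two measured steps show what putting a methyl on the aromatic ring did: an at least 6.0-fold lower number from compound 1 to compound 2 (0.77 log units; beyond the scatter), and an at least 4.7-fold lower number from compound 1 to compound 3 (0.67 log units; beyond the scatter). Compound 4 keeps that methyl, so the gain seen in those steps should largely remain. Among the compounds with values here, the closest precedent is moving the methyl around the same ring, and that move gave only a 1.3-fold higher number from compound 2 to compound 3 (0.10 log units; within the scatter). Within the data shown here, no measured compound carries the methyl in this new spot, so this step remains uncertain and the range stays wide.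

The expected change is small, within the scatter: a 1.1-fold higher number from compound 3 to compound 4 (0.04 log units; within the scatter). For compound 4 the estimated value is 55 uM, with an expected range from 25 uM to 150 uM.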

Compound 4, concentration for half-maximal effect: 40.9 uM
Beside the measured number, compound 4's estimate is 1.3-fold (0.13 log units) above it; measured number inside the range.
By their numbers in this assay, from the lowest: compounds 2, 4 and 3 (each within the scatter of the next). At a limit, above all of these: compound 1.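

In this assay, moving the methyl to the 2-methylphenyl arrangement gives no readable change: a 1.2-fold lower number from compound 3 to compound 4 (0.08 log units; within the scatter), and a 1.0-fold higher number from compound 2 to compound 4 (0.02 log units; within the scatter). Across compounds 2, 3 and 4, the presence of the methyl on this phenyl ring goes with the lower numbers, while its place on that ring makes no difference that can be read, and the new 2-methylphenyl compound completes that picture, with an at least 5.7-fold lower number from compound 1 to compound 4 (0.76 log units; beyond the scatter). That step gives only a minimum size, since compound 1 stands at a limit of the assay and not at a number: the limit of > 236 uM in this assay, at which 1 of the 4 values shown sits.

The compounds shown leave open whether methyl is special or whether another group on this phenyl ring, such as methoxy, chlorine or a longer chain like ethyl, would serve as well or better. From the compounds shown here alone, it also stays open whether a second methyl on the ring, or an amine in its place, could bring the number well below those of compounds 2, 3 and 4.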